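The source may report more compounds than this note shows. Statements on the series, on what has been measured and on what is new or still open speak of the compounds shown alone.

Among the measured compounds shown here, compound 1, `CCOc1ccc(NC2=CC(=O)c3ncncc3C2=O)cc1`, is the only compound in this set with a number rather than a limit; in a functional assay on HCT-15 cells (Homo sapiens) for cytotoxicity, read by MTT assay, with a stated time of 72 h (a higher number here means a weaker inhibitor, a lower number a stronger inhibitor), compound 1 gives 0.02 ug/mL. Compound 2, `O=C1C(Nc2ccc(Cl)cc2)=CC(=O)c2ncncc21`, reached the floor of the assay: its value in this assay of < 0.01 ug/mL is a limit, not a number, as the limit of < 0.01 ug/mL in this assay, at which 1 of the 2 values shown sits, states. For the measured compounds named here, the one measured step, an at least 2.0-fold lower number from compound 1 to compound 2 (0.30 log units; that floor lies within the scatter), therefore gives only a floor. Compound 3, `Cc1ccc(NC2=CC(=O)c3ncncc3C2=O)cc1`, differs from compound 1 by methyl in place of ethoxy on an aromatic carbon. Going by the values given here, no measured step in this set exchanges ethoxy for methyl, so the chloro step is the only guide, and its floor sits within the scatter. Compound 3 is therefore expected to stay close to compound 1, with an estimated step of no change at the digits printed from compound 1 to compound 3 (within the scatter) in this assay. The estimate for compound 3 in this assay is 0.02 ug/mL, with a range from 0.008 ug/mL to 0.05 ug/mL.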

Compound 3, half-maximal inhibitory concentration: 0.01 ug/mL
For compound 3 the middle estimate is 2.0-fold (0.30 log units) above the measured one, and the stated range covers the measured number.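

In this assay, putting methyl in place of ethoxy on this aromatic carbon, para to a large group, gives a 2.0-fold lower number from compound 1 to compound 3 (0.30 log units; within the scatter). Among the compounds shown here, this is the first readable step at this position: the replacement removes two heavy atoms and the one hydrogen-bond acceptor of ethoxy, yet the number stays within the scatter of compound 1. Compound 2 stands at a limit rather than a number: the limit of < 0.01 ug/mL in this assay, at which 1 of the 3 values shown sits. Putting methyl in place of chloro on this aromatic carbon therefore gives only a number no lower from compound 2 to compound 3 (the limit leaves the size open).

From the compounds shown here alone, how chloro and methyl truly rank at this position therefore remains open. Also open, going by these compounds, is whether an amine, a carboxylic acid or a longer chain on this aromatic carbon would keep the number in the same range.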